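The compounds below may be only part of what the source reports. "The series", "measured", "known", "first", "only" and "open" are said of these compounds alone.

Measured compounds:
Compound 1, `CC(Oc1ccc(Oc2ccc(F)cc2)cc1)C(=O)Cn1nnc(-c2ccc(Cl)cc2)n1`, in a physicochemical assay for lipophilicity, read by HPLC, tested at 5 mM; a lower number here means a more polar compound, a higher number a more lipophilic compound: 6.2.
Compound 2, `CCCCCCCCc1ccc(OC(C)C(=O)Cn2nnc(-c3ccc(C(=O)OC)cc3)n2)cc1`, in this assay: > 8, which is a limit of the assay, (the limit of > 8 in this assay, at which 1 of the 3 values shown sits).
Compound 3, `COC(=O)c1ccc(-c2nnn(CC(=O)C(C)Oc3ccc(Oc4ccc(F)cc4)cc3)n2)cc1`, in this assay: 5.4.

Compound 3 gives the lowest of the two numbers in this assay; its nearest neighbour is compound 1, and the step is a number 0.80 log units lower from compound 1 to compound 3 (beyond the scatter). The other measured step involving compound 3 is a number at least 2.60 log units lower from compound 2 to compound 3 (beyond the scatter), which is large; it brings the 4-fluorophenoxy group into the series but sets it against octyl, not against phenyl. Compound 4, `COC(=O)c1ccc(-c2nnn(CC(=O)C(C)Oc3ccc(-c4ccccc4)cc3)n2)cc1`, differs from compound 3 in one place: phenyl in place of 4-fluorophenoxy on an aromatic carbon. Going by the values given here, no measured step sets phenyl against 4-fluorophenoxy, so the two measured steps give only the frame: the change is on the same aromatic carbon as in the large step, but between two aromatic groups of similar count. A step in this assay of no more than modest size is therefore expected, if anything downward, as a number 0.30 log units lower from compound 3 to compound 4 (within the scatter). Compound 4 is accordingly estimated at 5.1, between 4.5 and 5.7.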

Compound 4, partition coefficient: 5.4
Compound 4: the middle estimate sits 0.30 log units below what was measured; low and high end bracket the measured number.
By their numbers in this assay, from the lowest: compounds 3 and 4 (each within the scatter of the next); then compound 1. At a limit, above all of these: compound 2.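

At this aromatic carbon, phenyl in place of 4-fluorophenoxy gives, in this assay, no change at the digits printed from compound 3 to compound 4 (within the scatter), so the oxygen and fluorine of the group that leaves make no difference that can be read here. Octyl can now be set against phenyl as well as against 4-fluorophenoxy, and that step is a number at least 2.60 log units lower from compound 2 to compound 4 (beyond the scatter), which places both aromatic groups on the same side of octyl. Compound 2 stands at a limit of the assay, so the true size of both octyl steps stays unknown: the limit of > 8 in this assay, at which 1 of the 4 values shown sits.

The compounds shown leave open whether phenyl and 4-fluorophenoxy stay level when chloro replaces methoxycarbonyl on the other aromatic ring. They also leave open how a shorter alkyl chain, an amine or a carboxylic acid would read at this aromatic carbon.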